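Anilinoquinazolines with nitroimidazole tails: aniline swap

The source may report more compounds than this note shows. Statements on the series, on what has been measured and on what is new or still open speak of the compounds shown alone.

Measured so far:
compound 1 `COc1cc2ncnc(Nc3cccc(Br)c3)c2cc1OCCCn1ccnc1[N+](=O)[O-]` — 4480 nM
compound 2 `COc1cc2ncnc(Nc3ccc(F)c(Cl)c3)c2cc1OCCCn1c([N+](=O)[O-])cnc1C` — 23200 nM

In a functional assay on HT-29 cells (Homo sapiens) for cytotoxicity, read by sulforhodamine B assay, with a stated time of 72 h (a higher number here means a weaker inhibitor, a lower number a stronger inhibitor), compound 2 gives the higher of the two numbers; compound 1 gives the lower one, and the gap between them is beyond the scatter. The two compounds differ in more than one place, so no single step can be read from them.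

Compound 3 `COc1cc2ncnc(Nc3cccc(Br)c3)c2cc1OCCCn1c([N+](=O)[O-])cnc1C` is the next member: 3-bromophenyl in place of 3-chloro-4-fluorophenyl on a nitrogen on an aromatic ring. The step from compound 2 to compound 3 in this assay is expected to go toward a lower number, of modest size, since compound 1, which carries the same 3-bromophenyl group, gives 4480 nM. For compound 3 the expected value is 9000 nM, within 3000 nM to 25000 nM, a step of a 2.6-fold lower number from compound 2 to compound 3 (0.41 log units; beyond the scatter).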

Compound 3, half-maximal inhibitory concentration: 15700 nM
Estimate against measurement, compound 3: 1.7-fold (0.24 log units) below, within the range that was stated.
By their numbers in this assay, from the lowest: compound 1; then compounds 3 and 2 (each within the scatter of the next).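

In this assay, the aniline change gives a 1.5-fold lower number from compound 2 to compound 3 (0.17 log units; within the scatter), so 3-bromophenyl and 3-chloro-4-fluorophenyl on a nitrogen on an aromatic ring cannot be told apart in this pair. The tail change does register: 2-methyl-5-nitro-1H-imidazol-1-yl in place of 2-nitro-1H-imidazol-1-yl gives a 3.5-fold higher number from compound 1 to compound 3 (0.54 log units; beyond the scatter). Nothing available explains either step.

Going by these compounds, whether the tail step holds with 3-chloro-4-fluorophenyl remains open. Also open, on these data alone, is how a morpholine at the end of the chain, or a longer chain, would read in this assay.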